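Replacing the diene terminus of compound 1 with hexyl

The source may report more compounds than this note shows. Statements on the series, on what has been measured and on what is new or still open speak of the compounds shown alone.

Among the measured compounds shown here, in a functional assay on PC-3 cells (Homo sapiens) for inhibition (a higher number here means a weaker inhibitor of growth, a lower number a stronger inhibitor of growth), compound 1 `C=C/C=C\[C@H](C)[C@H](OC(N)=O)[C@@H](C)[C@H](O)CC/C=C\C(C)[C@@H](O)[C@@H](C)/C=C\CC[C@@H]1O[C@@H](OC)[C@H](C)[C@@H](OCOC)[C@@H]1C` gives 15 nM, the only numerical value so far. Compound 2 `COCOC1=C(C)C(=O)O[C@@H](CC/C=C\[C@H](C)[C@H](O)C(C)/C=C\CC[C@@H](O)[C@H](C)[C@@H](OC(N)=O)C(C)C)[C@H]1C` is reported only as a limit, > 50 nM. For the measured compounds named here, no step between measured compounds is available, so the expectation below rests on one value and the structural change alone. Compound 3 `CCCCCC[C@H](OC(N)=O)[C@@H](C)[C@H](O)CC/C=C\C(C)[C@@H](O)[C@@H](C)/C=C\CC[C@@H]1O[C@@H](OC)[C@H](C)[C@@H](OCOC)[C@@H]1C` keeps the core of compound 1 and carries hexyl in place of 1-methylpenta-2,4-dien-1-yl on a saturated chain carbon bound to an oxygen next to a carbonyl group and a saturated chain carbon. Starting from compound 1 at 15 nM, a weakening in this assay beyond the usual scatter is expected, with considerable uncertainty. The expected change is a 4.0-fold higher number from compound 1 to compound 3 (0.60 log units; beyond the scatter). For compound 3 the estimated value is 60 nM, with an expected range of 15 nM to 300 nM.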

Compound 3, concentration for 50% growth inhibition: > 50 nM
Compound 3: a limit, no number; the forecaster's own chance of this, stated with the estimate: 35%; the middle value lies beyond the limit too.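

In this assay, the series gains its first comparison that differs in one place: hexyl in place of 1-methylpenta-2,4-dien-1-yl on a saturated chain carbon bound to an oxygen next to a carbonyl group and a saturated chain carbon gives an at least 3.3-fold higher number from compound 1 to compound 3 (0.52 log units; beyond the scatter). The heavy-atom count of the group is unchanged, so growth inhibition at this position depends on more than the size of the group as counted here. Compound 3 is reported only as a limit, > 50 nM, so the full size of the loss cannot be read: the limit of > 50 nM in this assay, at which 2 of the 3 values shown sit.

On these data alone, it remains open whether the double bonds, the methyl branch or the defined stereocentre accounts for the step. 1-Methylpentyl at this place would keep the branch without the double bonds, and penta-2,4-dien-1-yl would keep the double bonds without the branch.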